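The compounds below may be only part of what the source reports. "The series", "measured", "known", "first", "only" and "open" are said of these compounds alone.

Compound 1, with the structure `Cc1cc(C(=O)NCN2CCC(c3cccc[n+]3[O-])CC2)ccc1F`, was examined in a functional assay on HEK293 cells for agonist activity at D(4) dopamine receptor (Homo sapiens), read by FLIPR (a lower number here means a smaller maximal response, a higher number a larger maximal response), and gave 67%. That number is the highest of the three measured values in this series, though the margin over its nearest neighbour is slim: compound 2, with the structure `O=C(CN1CCC(c2cccc[n+]2[O-])CC1)Nc1ccc(F)cc1C(F)(F)F`, gave 65% in this assay, a value within the scatter of compound 1. Compound 3, with the structure `O=C(CN1CCC(c2ccccn2)CC1)Nc1c(Cl)cc(Cl)cc1Cl`, gave 45% in this assay, and here the gap to compound 1 lies beyond the scatter. For the measured compounds named here, no two of these measured compounds differ in only one place, so no single-point step has been measured.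

Compound 4, with the structure `Cc1cc(C(=O)NCN2CCC(c3cccc[n+]3[O-])CC2)ccc1Cl`, has not yet been measured. It differs from compound 1 in one place:

chloro in place of fluoro on an aromatic carbon

One halogen atom is exchanged for another at the same aromatic carbon, with no change in ring count, donors, acceptors or charge. With nothing measured to anchor such an exchange, the step from compound 1 to compound 4 is expected to be small, and most likely not beyond the scatter, as a number 2 percentage points lower from compound 1 to compound 4 (within the scatter) expresses. Compound 4 is therefore estimated to give 65% in this assay, within a range from 50% to 80%.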

Compound 4, largest response reached (reported as efficacy), in percent of the reference or control that the assay uses: 62%
For compound 4 the middle estimate is 3 percentage points above the measured one; the measured number falls inside the stated range.
By their numbers in this assay, from the lowest: compound 3; then compounds 4, 2 and 1 (each within the scatter of the next).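

For the compounds shown here, the exchange of 4-fluoro-3-methylphenyl for 4-chloro-3-methylphenyl gives the series its first single-point step in this assay, and it reads as a number 5 percentage points lower from compound 1 to compound 4 (within the scatter), which the earlier compounds, all differing in more than one place, could not provide. On this aromatic carbon, ortho to a methyl group and para to a large group, the two halogens therefore cannot be told apart by maximal response, at least on the core of compound 1, so fluoro is not singled out here as the only halogen compatible with a response of this size. No measurement available here explains why the exchange behaves this way.

What the compounds shown leave open is how far this position accepts other substituents, such as a bromo group, a methoxy group, a nitrile or plain hydrogen, and whether the methyl group alongside the halogen has any part in the result. Going by these compounds, it also remains open whether chloro in place of fluoro would read the same way on a different core, since this single pair cannot show a pattern across the series.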